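Series notes: the step from compound 3 to compound 4

This account rests on a few compounds, and the source may have more. Where it says the series, first, only, none or still open, it means among the compounds named here.

Measured so far, with the value in an assay for inhibition of 15-hydroxyprostaglandin dehydrogenase [NAD(+)] (Homo sapiens), read by fluorescence, with a stated time of 15 min, in the presence of a further agent that is not named here; a higher number here means a weaker inhibitor, a lower number a stronger inhibitor:
compound 1, `CCCC[S+]([O-])c1sc2nc(-c3nccs3)cc(-c3ccc(C(=O)OC)cc3)c2c1N`, gives 15.1 nM
compound 2, `CCCC[S+]([O-])c1sc2nc(-c3nccs3)cc(-c3ccc(CNS(C)(=O)=O)cc3)c2c1N`, gives 4.6 nM
compound 3, `CCCC[S+]([O-])c1sc2nc(-c3nccs3)cc(-c3ccc(CCO)cc3)c2c1N`, gives 2.9 nM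

Compound 3 holds the lowest number of the three. The step of a 5.2-fold lower number from compound 1 to compound 3 (0.72 log units; beyond the scatter) lies beyond the scatter, whereas the step of a 1.6-fold lower number from compound 2 to compound 3 (0.20 log units; within the scatter) does not, so compound 3 and compound 2 cannot be separated on these numbers; only compound 1 stands clearly apart.

Compound 4, `CCCC[S+]([O-])c1sc2nc(-c3nccs3)cc(-c3ccc(COC(=O)CN(C)C)cc3)c2c1N`, is not yet measured. It differs from compound 3 by (((dimethylamino)methyl)carbonyl)oxy in place of hydroxymethyl on a saturated chain carbon bound to an aromatic carbon. Going by the values given here, the change removes the one hydrogen-bond donor of compound 3 and adds acceptors, as the counts show.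

Among the compounds with values here, two measured steps bear on it. The step of a 5.2-fold lower number from compound 1 to compound 3 (0.72 log units; beyond the scatter) shows that exchanging methoxycarbonyl for 2-hydroxyethyl lowered the number; compound 4 moves back toward a carbonyl-bearing group without a donor, so a shift in the other direction, toward compound 1, is the nearest reading. The step of a 1.6-fold lower number from compound 2 to compound 3 (0.20 log units; within the scatter) shows that swapping one polar terminus for another changed little, which argues for a small step. Taken together, a modest rise in number is expected, a 2.2-fold higher number from compound 3 to compound 4 (0.35 log units; beyond the scatter). For compound 4 in this assay the estimate is 6.5 nM, with a range from 2.5 nM to 18 nM.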

Compound 4, half-maximal inhibitory concentration: 3.5 nM
The estimate for compound 4 lay 1.9-fold (0.27 log units) above the measured number; measured number inside the range.
By their numbers in this assay, from the lowest: compounds 3, 4 and 2 (each within the scatter of the next); then compound 1.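

In this assay, the step of a 1.2-fold higher number from compound 3 to compound 4 (0.08 log units; within the scatter) shows that the position on a saturated chain carbon bound to an aromatic carbon accepts the much larger (((dimethylamino)methyl)carbonyl)oxy in place of hydroxymethyl, and that the hydrogen-bond donor leaving with hydroxymethyl is not required to keep the number in this range. The step of a 1.3-fold lower number from compound 2 to compound 4 (0.12 log units; within the scatter) adds a third, quite different group to methanesulfonamido and hydroxymethyl on this saturated chain carbon, and the three compounds cannot be separated on these numbers. The step of a 4.3-fold lower number from compound 1 to compound 4 (0.63 log units; beyond the scatter) stays beyond the scatter, so a carbonyl and the lack of a donor in this group do not by themselves go with the higher number seen with methoxycarbonyl on the aromatic carbon.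

Open, from the compounds shown here alone, is whether this tolerance extends to a carboxylic acid, a primary amine or a longer chain ending in dimethylamino, and whether the dimethylamino nitrogen contributes anything, which a methoxyacetyl group in its place would test. Nothing available here explains why such different groups give numbers this close.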